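Aryl swap on the nine-membered ring series

The source may hold more compounds than are shown below. What is called first, only, known or untested is meant among the compounds shown, and "the series" means these compounds.

Measured in a functional assay on A549 cells (Homo sapiens) for antiproliferative activity, read by MTT assay, with a stated time of 72 h; a lower number here means a stronger inhibitor, a higher number a weaker inhibitor:
- compound 1 `COc1cc2ncnc(Nc3ccc(Br)cc3F)c2cc1OCCCN1CCNCCNCCNCC1`: 15200 nM
- compound 2 `COc1cc2ncnc(Nc3ccc(F)c(Br)c3)c2cc1OCCCN1CCNCCNCCNCC1`: 11800 nM
- compound 3 `COc1cc2ncnc(Nc3ccc(F)c(Br)c3)c2cc1OCCCN1CCNCCNCC1`: 34300 nM

Compound 3 has the highest number of the three in this assay, beyond the scatter from both others. Next is compound 4 `COc1cc2ncnc(Nc3ccc(Cl)cc3Cl)c2cc1OCCCN1CCNCCNCC1`, with this change: 2,4-dichlorophenyl in place of 3-bromo-4-fluorophenyl on a nitrogen on an aromatic ring. The ring on the chain stays as in compound 3, so a 2.9-fold higher number from compound 2 to compound 3 (0.46 log units; beyond the scatter) does not bear on this change. For the measured compounds named here, the only measured swap of the group on the nitrogen is a 1.3-fold lower number from compound 1 to compound 2 (0.11 log units; within the scatter), and it stayed within the scatter. Neither compound in that step carries 2,4-dichlorophenyl, so the support is thin. The expected change is small, a 1.1-fold lower number from compound 3 to compound 4 (0.06 log units; within the scatter), with no step beyond the scatter anticipated. Compound 4 is estimated at 30000 nM, with an expected range of 14000 nM to 60000 nM.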

Compound 4, half-maximal inhibitory concentration: 44200 nM
The estimate for compound 4 lay 1.5-fold (0.17 log units) below the measured number; measured number inside the range.
By their numbers in this assay, from the lowest: compounds 2 and 1 (each within the scatter of the next); then compounds 3 and 4 (each within the scatter of the next).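

In this assay, for the compounds shown here, the aryl swap on the nine-membered ring gives a 1.3-fold higher number from compound 3 to compound 4 (0.11 log units; within the scatter), so 2,4-dichlorophenyl, absent from the earlier compounds, leaves the number within the scatter. With a 1.3-fold lower number from compound 1 to compound 2 (0.11 log units; within the scatter), this makes one swap within the scatter on each ring, the larger one and the nine-membered one. No measurement at hand gives a reason for these small steps.

On these data alone, whether 2,4-dichlorophenyl behaves the same way on the larger ring remains open. So does the effect of an unsubstituted phenyl or a pyridyl group on the nitrogen.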